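Amine variants in the series: the step from compound 2

The compounds below may be only part of what the source reports. "The series", "measured", "known", "first", "only" and "open" are said of these compounds alone.

Values in a functional assay on MCF7 cells (Homo sapiens) for inhibition, read by MTT assay, with a stated time of 72 h; on this read-out lower numbers stand for stronger inhibition and higher numbers for weaker inhibition:
compound 1 `C/C1=C\CC[C@@]2(C)O[C@@H]2[C@H]2OC(=O)[C@@H](CN3CCCC3)[C@@H]2C[C@H]1O`: 21000 nM
compound 2 `C/C1=C\CC[C@@]2(C)O[C@@H]2[C@H]2OC(=O)[C@@H](CN3CCN(C)CC3)[C@@H]2C[C@H]1O`: 33000 nM
compound 3 `C/C1=C\CC[C@@]2(C)O[C@@H]2[C@H]2OC(=O)[C@@H](CN(C)CCN(C)C)[C@@H]2C[C@H]1O`: 14000 nM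

The data show a 1.6-fold higher number from compound 1 to compound 2 (0.20 log units; within the scatter), so compound 2 stands level with compound 1. Compound 3 stands apart, with a 2.4-fold lower number from compound 2 to compound 3 (0.37 log units; beyond the scatter). Compound 4 `C/C1=C\CC[C@@]2(C)O[C@@H]2[C@H]2OC(=O)[C@@H](CN3CCN(c4ccccc4F)CC3)[C@@H]2C[C@H]1O` brings 2-fluorophenyl in place of methyl on an amine nitrogen in a ring. The nearest evidence is the exchange of the whole amine, which gave a 1.5-fold lower number from compound 1 to compound 3 (0.18 log units; within the scatter) as well as the two steps above. None of these steps introduces an aromatic ring, so they bear on the change only loosely. In this assay a small move to lower numbers is expected, possibly none beyond the scatter. The estimated step is a 1.8-fold lower number from compound 2 to compound 4 (0.26 log units; within the scatter). For compound 4 the expected value is 18000 nM, with an estimated range of 7000 nM to 40000 nM.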

Compound 4, half-maximal inhibitory concentration: 24000 nM
Compound 4: middle estimate off by 1.3-fold (0.12 log units), on the low side, and the stated range covers the measured number.
By their numbers in this assay, from the lowest: compounds 3, 1, 4 and 2 (each within the scatter of the next, the first and the last beyond it).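

On the amine nitrogen in the ring, 2-fluorophenyl in place of methyl puts the first aromatic ring of the series at this position, and this assay gives a 1.4-fold lower number from compound 2 to compound 4 (0.14 log units; within the scatter). This position therefore accepts seven heavy atoms in place of one without a step beyond the scatter in this assay. No measurement at hand accounts for this result.

What the compounds shown leave open is the share of the fluorine in this result. Phenyl or 4-fluorophenyl on the same nitrogen would separate the fluorine and its place from the aromatic ring itself.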